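The compounds below may be only part of what the source reports. "The series", "measured", "known", "first", "only" and "open" are said of these compounds alone.

Of the compounds shown here, three sharing one core have been measured in an assay on isolated protein for inhibition of Rho-associated protein kinase 2 (Homo sapiens), read by scintillation counting, radiometric assay and 33P incorporation, with a stated time of 40 min, in the presence of a further agent that is not named here; on this read-out lower numbers stand for stronger inhibition and higher numbers for weaker inhibition. Compound 1 `O=C(COc1ccc2c(=O)ccoc2c1)Nc1cccc(NC(=O)c2ccc(Br)cc2)c1` gives 49 nM. Compound 2 `CC(C)(C)c1cc(C(=O)Nc2cccc(NC(=O)COc3ccc4c(=O)ccoc4c3)c2)no1` gives 5 nM, and the change a 9.8-fold lower number from compound 1 to compound 2 (0.99 log units; beyond the scatter). Compound 3 `Cn1ccc(S(=O)(=O)Nc2cccc(NC(=O)COc3ccc4c(=O)ccoc4c3)c2)n1` gives 1350 nM, the highest number of the three, and the steps of a 28-fold higher number from compound 1 to compound 3 (1.44 log units; beyond the scatter) and a 270-fold higher number from compound 2 to compound 3 (2.43 log units; beyond the scatter) show how far it sits from the other two.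

Compound 4 `O=C(COc1ccc2c(=O)ccoc2c1)Nc1cccc(NS(=O)(=O)c2ccc(C(F)(F)F)cc2)c1` is not yet measured. It differs from compound 3 in one place: 4-(trifluoromethyl)phenyl in place of 1-methyl-1H-pyrazol-3-yl on a sulfonyl sulfur. Within the data shown here, the sulfonamide link of compound 3 is kept, so no measured step matches this change directly. The nearest guide is the comparison of compound 1 with compound 3, where a six-membered carbon-only ring with a bromine on an amide carbonyl stood against a five-membered ring with two hetero atoms on a sulfonyl sulfur, and the step was large. Compound 4 returns to a six-membered carbon-only ring while keeping the sulfonyl. Some recovery toward the number of compound 1 is therefore expected, but with real uncertainty, since the amide-to-sulfonamide part of that step cannot be separated out. For compound 4 the expected step is a 3.9-fold lower number from compound 3 to compound 4 (0.59 log units; beyond the scatter), and the estimated value is 350 nM, within a range from 60 nM to 2000 nM.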

Compound 4, half-maximal inhibitory concentration: 6890 nM
Compound 4: the middle estimate sits 20-fold (1.29 log units) below what was measured; the whole stated range lies below it.
By their numbers in this assay, from the lowest: compound 2; then compound 1; then compound 3; then compound 4.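

Replacing 1-methyl-1H-pyrazol-3-yl with 4-(trifluoromethyl)phenyl on the sulfonyl sulfur gives a 5.1-fold higher number from compound 3 to compound 4 (0.71 log units; beyond the scatter) in this assay. So with the sulfonyl kept, this six-membered ring of carbon only does not bring the number down. Across the four compounds, the two with a sulfonyl link, compound 3 and compound 4, now hold the two highest numbers, and no compound goes against this, while the data give no explanation for the rise from compound 3 to compound 4.

The compounds shown contain no pair that carries the same ring on a carbonyl carbon and on a sulfonyl sulfur, so the share of the link itself in these numbers remains open. As far as these compounds go, it is also open whether the number on the sulfonyl sulfur would change with a plain phenyl carrying no trifluoromethyl, or with a ring bearing an amine or a carboxylic acid.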